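The source may hold more compounds than are shown below. What is called first, only, known or untested is meant among the compounds shown, and "the series" means these compounds.

Compound 2 `CS(=O)(=O)Nc1ccc(-n2cc(COc3ccccc3Cl)nn2)cc1Oc1ccccc1` gives 21100 nM in a functional assay on DU-145 cells (Homo sapiens) for inhibition, read by MTT assay, with a stated time of 48 h (a lower number here means a stronger inhibitor, a higher number a weaker inhibitor), the highest of the two numbers recorded; its nearest neighbour is compound 1 `CS(=O)(=O)Nc1ccc(-n2cc(OCc3ccccc3)nn2)cc1Oc1ccccc1`, which in this assay gives 10700 nM. Among the compounds with values here, the only measured step, a 2.0-fold higher number from compound 1 to compound 2 (0.29 log units; within the scatter), concerned the same part of the shared core. Compound 3 `CS(=O)(=O)Nc1ccc(-n2cc(COc3ccc(Cl)cc3)nn2)cc1Oc1ccccc1` differs from compound 2 by 4-chlorophenyl in place of 2-chlorophenyl on an oxygen on a saturated carbon. Within the data shown here, no measured step moves the chlorine around that ring, so because a 2.0-fold higher number from compound 1 to compound 2 (0.29 log units; within the scatter) stayed within the scatter, a step within the scatter is expected here too, a 1.2-fold lower number from compound 2 to compound 3 (0.07 log units; within the scatter). Compound 3 is therefore estimated at 18000 nM, within a range of 7000 nM to 45000 nM.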

Compound 3, half-maximal inhibitory concentration: 6400 nM
Beside the measured number, compound 3's estimate is 2.8-fold (0.45 log units) above it; the whole stated range lies above it.
By their numbers in this assay, from the lowest: compounds 3, 1 and 2 (each within the scatter of the next, the first and the last beyond it).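

In this assay the place of the chlorine on the ring on that oxygen does count: 4-chlorophenyl in place of 2-chlorophenyl, with the same atoms joined differently, gives a 3.3-fold lower number from compound 2 to compound 3 (0.52 log units; beyond the scatter) and is the first step shown to pass the scatter. The other new step, a 1.7-fold lower number from compound 1 to compound 3 (0.22 log units; within the scatter), stays within it, so (4-chlorophenoxy)methyl and benzyloxy cannot be told apart here.

On these data alone, it remains open whether 3-chlorophenyl, or 4-methoxyphenyl, on the same oxygen would follow compound 3 or compound 2. No evidence is at hand that bears on what lies behind this step.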